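Swapping an aryl cap on a histamine antagonist chain

This account rests on a few compounds, and the source may have more. Where it says the series, first, only, none or still open, it means among the compounds named here.

Three compounds share a long chain that ends in a piperidine-bearing aryl ether and carries a cyanoguanidine in its middle; they differ in the group attached to an amine nitrogen at the other end. In a functional assay on cardiac atrium for antagonist activity at histamine H2 receptor (Cavia porcellus), tested at 0.3 uM (on this read-out higher numbers stand for higher potency (the scale is a negative logarithm) and lower numbers for lower potency), compound 2 `N#CN/C(=N\CCNc1ccc(N=[N+]=[N-])cc1[N+](=O)[O-])NCCCCOc1cccc(CN2CCCCC2)c1` gives 7.47. Compound 3 `N#CN/C(=N\CCNC(=O)c1ccc(N=[N+]=[N-])cc1)NCCCCOc1cccc(CN2CCCCC2)c1` gives 7.54 in this assay, and compound 1 `N#CN/C(=N\CCCNc1ccc(N=[N+]=[N-])cc1[N+](=O)[O-])NCCCOc1cccc(CN2CCCCC2)c1`, which has a shorter link on one side and a longer one on the other, gives 6.79. Compound 2 therefore sits close to compound 3 and clearly above compound 1.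

Compound 4 `N#CN/C(=N\CCNC(=O)c1ccc(N)c(I)c1)NCCCCOc1cccc(CN2CCCCC2)c1` is not yet measured. It differs from compound 2 in one place: (4-amino-3-iodophenyl)carbonyl in place of 4-azido-2-nitrophenyl on an amine nitrogen. Among the measured compounds shown here, the only measured step that bears on this is the one from compound 2 to compound 3, which also replaced the 4-azido-2-nitrophenyl group with an aryl carbonyl on that nitrogen, and it gave a number 0.07 log units higher from compound 2 to compound 3 (within the scatter). Since that change left this assay's read-out essentially untouched, the expectation for compound 4 is a step of about a number 0.03 log units higher from compound 2 to compound 4 (within the scatter), that is, no shift beyond the scatter. Compound 4 is accordingly estimated at 7.5, with a likely range from 7 to 8.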

Compound 4, negative logarithm of the antagonist equilibrium constant: 7.35
Compound 4: middle estimate off by 0.15 log units, on the high side; the range from low to high includes it.
By their numbers in this assay, from the lowest: compound 1; then compounds 4, 2 and 3 (each within the scatter of the next).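

In this assay, a second, quite different cap on the amine nitrogen gives a number 0.12 log units lower from compound 2 to compound 4 (within the scatter), so the read-out does not separate the (4-amino-3-iodophenyl)carbonyl group from the 4-azido-2-nitrophenyl group, even though the entering group brings an iodine and a hydrogen-bond donor. Among the compounds shown here, with the carbonyl kept in place, 4-amino-3-iodophenyl in place of 4-azidophenyl gives a number 0.19 log units lower from compound 3 to compound 4 (within the scatter), which is the first view of a change to the aryl group alone; all the earlier compounds carry an azido group and compound 4 has none, yet compound 4 reads alike with compound 2 and compound 3, so in this set the azido group is not needed to keep the read-out at this level. Nothing available here explains why these caps read alike.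

The amino group and the iodine enter together, so the compounds shown cannot tell what each does alone, and a plain benzoyl cap or a 4-aminophenyl carbonyl cap would be needed to pull them apart. On these data alone, it also remains open whether this latitude extends to a cap without an aromatic ring, such as a cyclohexyl carbonyl, or to one bearing a carboxylic acid.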